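Exchanging the benzyl substituent for a trimethoxybenzyl group

This account rests on a few compounds, and the source may have more. Where it says the series, first, only, none or still open, it means among the compounds named here.

Of the compounds shown here, three sharing one core have been measured in a functional assay on A549 cells (Homo sapiens) for inhibition, read by MTT assay, with a stated time of 48 h; on this read-out higher numbers stand for weaker inhibition and lower numbers for stronger inhibition. Compound 1 `COc1cc(-c2nc3cc(/C=C4\SC(=O)N(CC(=O)N5CCCCC5)C4=O)ccc3[nH]2)cc(OC)c1OC` gives 980 nM in this assay. Compound 2 `COc1cc(-c2nc3cc(/C=C4\SC(=O)N(CC(=O)N5CCCC5)C4=O)ccc3[nH]2)cc(OC)c1OC` gives 910 nM in this assay. Compound 3 `COc1cc(-c2nc3cc(/C=C4\SC(=O)N(Cc5cccc(C)c5)C4=O)ccc3[nH]2)cc(OC)c1OC` gives 930 nM in this assay, which places it second highest of the three, though its distance to either neighbour is within the scatter: a 1.1-fold lower number from compound 1 to compound 3 (0.02 log units; within the scatter) and a 1.0-fold higher number from compound 2 to compound 3 (0.01 log units; within the scatter). The step from compound 1 to compound 2, a 1.1-fold lower number from compound 1 to compound 2 (0.03 log units; within the scatter), is likewise within the scatter. All three changes concern the group on the saturated chain carbon bound to the amide-type nitrogen in the ring, and none of them moved the number beyond the scatter.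

Compound 4 `COc1cc(CN2C(=O)S/C(=C\c3ccc4[nH]c(-c5cc(OC)c(OC)c(OC)c5)nc4c3)C2=O)cc(OC)c1OC` differs from compound 3 at that same place: 3,4,5-trimethoxyphenyl in place of 3-methylphenyl on a saturated chain carbon bound to an amide-type nitrogen in a ring. Since every measured change at this position stayed within the scatter, compound 4 is expected to show a 1.0-fold lower number from compound 3 to compound 4 (0.01 log units; within the scatter), no step beyond the scatter. Compound 4 is therefore estimated at 900 nM in this assay, with a range from 400 nM to 2000 nM.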

Compound 4, half-maximal inhibitory concentration: 530 nM
The estimate for compound 4 lay 1.7-fold (0.23 log units) above the measured number; low and high end bracket the measured number.
By their numbers in this assay, from the lowest: compounds 4, 2, 3 and 1 (each within the scatter of the next).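

In this assay, the saturated chain carbon bound to an amide-type nitrogen in a ring also accepts 3,4,5-trimethoxyphenyl, which brings oxygen atoms and hydrogen-bond acceptors that 3-methylphenyl lacks, and the number stays within the scatter (a 1.8-fold lower number from compound 3 to compound 4 (0.24 log units; within the scatter)). The same holds when this group takes the place of either carbonyl-linked ring (a 1.7-fold lower number from compound 2 to compound 4 (0.23 log units; within the scatter)) and (a 1.8-fold lower number from compound 1 to compound 4 (0.27 log units; within the scatter)). Across these four compounds, the position therefore holds phenyl rings with and without methoxy groups as well as (pyrrolidin-1-yl)carbonyl and (piperidin-1-yl)carbonyl, and no step between them goes beyond the scatter.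

Going by these compounds, whether a carboxylic acid, an amine or a longer chain at this place would move the number beyond the scatter remains open. Nothing available explains why the numbers lie so close together.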